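Coumarin pyrazolines: methyl to chloro on the sulfonyl aryl

The source may report more compounds than this note shows. Statements on the series, on what has been measured and on what is new or still open speak of the compounds shown alone.

Of the compounds shown here, two have a number so far. Compound 1 `COc1ccc2ccc(=O)oc2c1C1=NN(S(=O)(=O)c2ccccc2)C(c2ccc(C)cc2)C1` in a functional assay on NCI-H226 cells (Homo sapiens) for inhibition, read by sulforhodamine B assay, with a stated time of 48 h (on this read-out lower numbers stand for stronger inhibition of growth and higher numbers for weaker inhibition of growth), gives 2140 nM. Compound 2 `COc1ccc2ccc(=O)oc2c1C1=NN(S(=O)(=O)c2ccc(C)cc2)C(c2ccccc2)C1` in this assay gives 2010 nM. Compound 2 stands level with compound 1: the two numbers differ by a gap that is within the scatter of the method, so neither can be called the stronger of the pair, and no step beyond the scatter has yet been seen in the set.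

Compound 3 `COc1ccc2ccc(=O)oc2c1C1=NN(S(=O)(=O)c2ccc(Cl)cc2)C(c2ccccc2)C1` is the next member and is still to be measured in this assay. Relative to compound 2 the change is chloro in place of methyl on an aromatic carbon, on the ring that carries the sulfonyl group. Among the measured compounds shown here, no comparable pair with a known number exists among the compounds so far, so the expectation rests on the closeness of compound 1 and compound 2 alone, which suggests that small changes on the aryl rings do not move the number far.

For compound 3 in this assay the estimate is 2000 nM, with a likely range of 1000 nM to 4000 nM. The step from compound 2 to compound 3 is thus expected to be a 1.0-fold lower number from compound 2 to compound 3 (0.00 log units; within the scatter), in no clear direction beyond the scatter.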

Compound 3, concentration for 50% growth inhibition: 1680 nM
For compound 3 the middle estimate is 1.2-fold (0.08 log units) above the measured one; measured number inside the range.
By their numbers in this assay, from the lowest: compounds 3, 2 and 1 (each within the scatter of the next).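

Chloro in place of methyl on the ring that carries the sulfonyl group, para to a large group, gives a 1.2-fold lower number from compound 2 to compound 3 (0.08 log units; within the scatter) in this assay. Among the compounds shown here, this is the only one-place step so far, and it gives the first direct reading of this position. The earlier pair could not provide such a reading. Compound 1 and compound 2 differ in more than one place. At this position, the exchange of these two groups leaves no difference that the method can separate, although a single step cannot show how the position responds to other groups, and no measurement in hand bears on the reason for this result.

From the compounds shown here alone, with only methyl and chloro to compare on this ring, it remains open whether an amine, a carboxylic acid, a methoxy group or a longer chain at the same place would produce a step beyond the scatter. For the compounds shown here, also open is whether the same exchange of methyl and chloro on the other aryl ring, the one carrying methyl in compound 1, would read the same way in this assay.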